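This account rests on a few compounds, and the source may have more. Where it says the series, first, only, none or still open, it means among the compounds named here.

Compound 2 `CC(C)n1cnc2c(NCc3cccc(O)c3)nc(NCCCO)nc21` gives 26000 nM in a functional assay on HOS cells (Homo sapiens) for cytotoxicity; on this read-out higher numbers stand for weaker inhibition and lower numbers for stronger inhibition. Compound 1 `CC(C)n1cnc2c(NCc3ccc(O)cc3)nc(NCCCO)nc21` gives 26000 nM in this assay, so the change 4-hydroxyphenyl in place of 3-hydroxyphenyl on a saturated chain carbon bound to a nitrogen on an aromatic ring made no change at the digits printed from compound 2 to compound 1 (within the scatter). Compound 3 `CC(C)C(CO)Nc1nc(NCc2cccc(O)c2)c2ncn(C(C)C)c2n1` gives 12000 nM in this assay, and its core differs from the core of compound 2 by 1-(hydroxymethyl)-2-methylpropyl in place of 3-hydroxypropyl on a nitrogen on an aromatic ring, a change that brought a 2.2-fold lower number from compound 2 to compound 3 (0.34 log units; beyond the scatter). Compound 4 `CC(C)C(CO)Nc1nc(NCc2ccc(O)cc2)c2ncn(C(C)C)c2n1` has not been measured in this assay. It differs from compound 3 by 4-hydroxyphenyl in place of 3-hydroxyphenyl on a saturated chain carbon bound to a nitrogen on an aromatic ring, the same change as that from compound 2 to compound 1, at the same place on a saturated chain carbon bound to a nitrogen on an aromatic ring. Because that earlier change gave no change at the digits printed from compound 2 to compound 1 (within the scatter), compound 4 is expected to show no change at the digits printed from compound 3 to compound 4 (within the scatter). The estimate for compound 4 in this assay is 12000 nM, with an expected range from 6000 nM to 25000 nM.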

Compound 4, half-maximal inhibitory concentration: 12000 nM
Compound 4: the middle estimate sits on the measured number at the digits printed; measured number inside the range.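

In this assay, 4-hydroxyphenyl in place of 3-hydroxyphenyl brought no change at the digits printed from compound 3 to compound 4 (within the scatter), which matches the earlier step on the other core: the same change on two cores in this assay, no change at the digits printed (within the scatter) from compound 2 to compound 1 and no change at the digits printed (within the scatter) from compound 3 to compound 4, 1.0-fold (0.00 log units) apart, within the scatter of two such steps Likewise, 1-(hydroxymethyl)-2-methylpropyl in place of 3-hydroxypropyl brought a 2.2-fold lower number from compound 1 to compound 4 (0.34 log units; beyond the scatter), which also matches its earlier step: the same change on two cores in this assay, a 2.2-fold lower number (0.34 log units; beyond the scatter) from compound 2 to compound 3 and a 2.2-fold lower number (0.34 log units; beyond the scatter) from compound 1 to compound 4, 1.0-fold (0.00 log units) apart, within the scatter of two such steps Each change thus carried over between these two cores, but this rests on only four compounds and does not show that either change would carry to any other core. The compounds shown leave open what an amine or a carboxylic acid in place of the hydroxyl on the phenyl ring would do in this assay. They also leave open the effect of a longer chain in place of 3-hydroxypropyl.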